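The compounds below may be only part of what the source reports. "The series", "measured", "known", "first", "only" and "open" are said of these compounds alone.

Measured compounds:
Compound 1 `Cc1ccc(C(=O)N/N=C/c2cc(I)cc(I)c2O)cc1` — in a functional assay on HepG2 cells (Homo sapiens) for cytotoxicity, with a stated time of 24 h (on this read-out higher numbers stand for weaker inhibition and lower numbers for stronger inhibition), compound 1 gives > 25000 nM, a limit of the assay rather than a number.
Compound 2 `COc1ccc(C(=O)N/N=C/c2cc(I)cc(I)c2O)cc1` — in this assay compound 2 gives 45200 nM.

Compound 2 stands as the only number shown in this assay; the other value is a limit. The step that the limit leaves unreadable from compound 1 to compound 2 cannot be sized because of the limit of > 25000 nM in this assay, at which 1 of the 2 values shown sits.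

Compound 3 `CC(C)(C)c1ccc(C(=O)N/N=C/c2cc(I)cc(I)c2O)cc1` follows from compound 2 by tert-butyl in place of methoxy on an aromatic carbon. For the measured compounds named here, no measured step informs this change, since the single step from compound 1 to compound 2 is unreadable. In this assay the estimate for compound 3 is therefore anchored on compound 2 alone, with no directional expectation beyond the scatter, but a real chance that only a limit is returned. For compound 3 the expected step is a 1.1-fold lower number from compound 2 to compound 3 (0.05 log units; within the scatter). Compound 3 is estimated at 40000 nM, within 15000 nM to 120000 nM.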

Compound 3, half-maximal inhibitory concentration: 41600 nM
Compound 3: middle estimate off by 1.0-fold (0.02 log units), on the low side; the measured number falls inside the stated range.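

For the compounds shown here, at this position, para to a large group, the one readable step in this assay is a 1.1-fold lower number from compound 2 to compound 3 (0.04 log units; within the scatter). Tert-butyl and methoxy differ in heavy atoms and in hydrogen-bond acceptors, yet compound 2 and compound 3 cannot be told apart on this read-out, which the earlier pair could not show. The steps from compound 1 cannot be read, since compound 1 stands at a limit of the assay: the limit of > 25000 nM in this assay, at which 1 of the 3 values shown sits.

Where methyl stands relative to methoxy and tert-butyl therefore stays open. Also open, as far as these compounds go, is whether an amine or a carboxylic acid at this position would give a number clearly apart from those of compound 2 and compound 3.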